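This account rests on a few compounds, and the source may have more. Where it says the series, first, only, none or still open, it means among the compounds named here.

Measured in a functional assay on SMMC-7721 cells (Homo sapiens) for cytotoxicity, read by MTT assay, with a stated time of 4 days; a higher number here means a weaker inhibitor, a lower number a stronger inhibitor:
compound 1 `C=C1C(=O)[C@]23C[C@@]1(O)CC[C@H]2c1ccc(O)c(C)c1[C@@H]3Cn1cc(-c2ccccn2)nn1`, 1270 nM
compound 2 `C=C1C(=O)[C@]23C[C@@]1(O)CC[C@H]2c1ccc(O)c(C)c1[C@@H]3Cn1cc(-c2ccc(C(F)(F)F)cc2)nn1`, 1440 nM
compound 3 `C=C1C[C@]23C[C@@]1(O)CC[C@H]2c1ccc(OS(=O)(=O)c2ccc(C)cc2)c(C)c1[C@@H]3Cn1cc(-c2ccc(C(F)(F)F)cc2)nn1`, > 20000 nM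

The value for compound 3 in this assay is a limit of the assay, not a number; it is the one shown in the limit of > 20000 nM in this assay, at which 1 of the 3 values shown sits.

Compound 2 and compound 1 share a core and differ by one change, (pyridin-2-yl in place of 4-(trifluoromethyl)phenyl on an aromatic carbon); the step is a 1.1-fold lower number from compound 2 to compound 1 (0.05 log units; within the scatter).

The difference between the core of compound 3 and the core of compound 2 is not broken down here.

Compound 4 `C=C1C[C@]23C[C@@]1(O)CC[C@H]2c1ccc(OS(=O)(=O)c2ccc(C)cc2)c(C)c1[C@@H]3Cn1cc(-c2ccccn2)nn1` is not yet measured in this assay. It differs from compound 3 by pyridin-2-yl in place of 4-(trifluoromethyl)phenyl on an aromatic carbon, the same change as that from compound 2 to compound 1.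

Because the measured step of a 1.1-fold lower number from compound 2 to compound 1 (0.05 log units; within the scatter) lies within the scatter, the step to compound 4 is expected to be about a step that the limit leaves unreadable from compound 3 to compound 4. Compound 4 is therefore estimated at 30000 nM in this assay, most likely again reported only as a limit.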

Compound 4, half-maximal inhibitory concentration: > 20000 nM
Compound 4 ended at the assay's limit (the forecaster's own chance of this, stated with the estimate: 80%); the middle value lies beyond the limit too.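

Compound 3 and compound 4 each give only a limit, not a number, so no step between them can be read: the limit of > 20000 nM in this assay, at which 2 of the 4 values shown sit.

Still open, on these data alone, is whether pyridin-2-yl and 4-(trifluoromethyl)phenyl differ at all on the core of compound 3.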